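The compounds below may be only part of what the source reports. "The series", "measured", "known", "first", "only" and "open" are said of these compounds alone.

In a functional assay on MCF7 cells (Homo sapiens) for inhibition, read by MTT assay, with a stated time of 48 h (on this read-out higher numbers stand for weaker inhibition and lower numbers for stronger inhibition), compound 1 `COc1ccc(C(c2c[nH]c3ccc(Br)cc23)c2c[nH]c3ccc(Br)cc23)cc1OC` gives 7800 nM and compound 2 `Clc1ccc(C(c2c[nH]c3ccc(Br)cc23)c2c[nH]c3ccc(Br)cc23)cc1` gives 3500 nM. Compound 3 `OC[C@H]1O[C@@H](n2cc(C(c3ccc(Cl)cc3)c3cn([C@@H]4O[C@H](CO)[C@@H](O)[C@H](O)[C@H]4O)c4ccc(Br)cc34)c3cc(Br)ccc32)[C@H](O)[C@@H](O)[C@@H]1O` keeps the 4-chlorophenyl of compound 2 but is a much larger molecule. Compound 3 gives 53200 nM, the highest of the three numbers and so the weakest inhibition measured so far.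

Compound 4 `O=[N+]([O-])c1ccc(C(c2cn([C@@H]3O[C@H](CO)[C@@H](O)[C@H](O)[C@H]3O)c3ccc(Br)cc23)c2cn([C@@H]3O[C@H](CO)[C@@H](O)[C@H](O)[C@H]3O)c3ccc(Br)cc23)cc1` has not yet been measured. It differs from compound 3 by one swap, nitro in place of chloro on an aromatic carbon, para to a large group: nitro in place of chloro on an aromatic carbon.

Among the compounds with values here, only one measured step bears on this change. It also replaces a group on the same phenyl ring. That step is a 2.2-fold lower number from compound 1 to compound 2 (0.35 log units; beyond the scatter), which came with 4-chlorophenyl in place of 3,4-dimethoxyphenyl, and it is modest, only just beyond the scatter. Within the data shown here, it was measured on the smaller compounds, and no measured compound carries a nitro group, so it gives size but no reliable direction. In this assay, a step of about that size at most is therefore expected, with no clear direction and probably none beyond the scatter. The expected step is a 1.2-fold lower number from compound 3 to compound 4 (0.07 log units; within the scatter). For compound 4 the estimated value is 45000 nM, within an expected range of 18000 nM to 110000 nM.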

Compound 4, half-maximal inhibitory concentration: 66700 nM
Estimate against measurement, compound 4: 1.5-fold (0.17 log units) below, within the range that was stated.
By their numbers in this assay, from the lowest: compound 2; then compound 1; then compounds 3 and 4 (each within the scatter of the next).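

In this assay, nitro in place of chloro on the aromatic carbon para to a large group gives a 1.3-fold higher number from compound 3 to compound 4 (0.10 log units; within the scatter) and so leaves the two compounds indistinguishable on this read-out. Within the data shown here, the only earlier change on this ring, a 2.2-fold lower number from compound 1 to compound 2 (0.35 log units; beyond the scatter) in the smaller compounds, involved different groups and no nitro, so it could not show what this swap would do. The new step shows that, in the larger molecules, this position accepts a group of three heavy atoms with two hydrogen-bond acceptors in place of a single chlorine with no change beyond the scatter, and nothing measured here offers an explanation for that.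

Among these compounds, both compounds sit at the weak end of the numbers so far, so this one step cannot say whether nitro and chloro would also match on the smaller compound 2, whose number is far lower. It also leaves open whether a quite different group on this aromatic carbon, such as an amine or a carboxylic acid, would shift the number beyond the scatter.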